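The source may report more compounds than this note shows. Statements on the series, on what has been measured and on what is new or still open speak of the compounds shown alone.

Measured in a functional assay on A549 cells (Homo sapiens) for inhibition, read by MTT assay, with a stated time of 24 h; a higher number here means a weaker inhibitor, a lower number a stronger inhibitor:
- compound 1 `CC1(C)[C@H]2CC[C@]1(C)N(Cc1cn(-c3cccc(C#N)c3)nn1)C(=O)C2` gives 440 nM
- compound 2 `COc1cccc(-n2cc(CN3C(=O)C[C@@H]4CC[C@@]3(C)C4(C)C)nn2)c1` gives 240 nM

Only these two values exist so far. Compound 2 with 240 nM lies within the scatter of compound 1, so the pair cannot be ranked.

Compound 3 `Cc1cccc(-n2cc(CN3C(=O)C[C@@H]4CC[C@@]3(C)C4(C)C)nn2)c1` is still unmeasured. It differs from compound 2 in one place, with the shared core untouched: methyl in place of methoxy on an aromatic carbon. In words, this is methyl in place of methoxy on an aromatic carbon, or 3-methoxyphenyl to 3-methylphenyl.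

Among the measured compounds shown here, one measured step bears on this change: a 1.8-fold lower number from compound 1 to compound 2 (0.26 log units; within the scatter), with methoxy in place of cyano on the aromatic carbon. For the measured compounds named here, a single step is thin evidence, and no compound with methyl there has a value yet. On that basis, no step beyond the scatter is expected in this assay, and no direction can be favoured. The estimated step is a 1.2-fold higher number from compound 2 to compound 3 (0.07 log units; within the scatter), which is no real separation. Compound 3 is expected at 280 nM, within an estimated range of 110 nM to 700 nM for this value.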

Compound 3, half-maximal inhibitory concentration: 50 nM
For compound 3 the middle estimate is 5.6-fold (0.75 log units) above the measured one; measured number outside the range, below it.
By their numbers in this assay, from the lowest: compound 3; then compounds 2 and 1 (each within the scatter of the next).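

In this assay, the group on this aromatic carbon, meta to a large group, now separates the compounds, which the earlier pair could not show: methyl in place of methoxy gives a 4.8-fold lower number from compound 2 to compound 3 (0.68 log units; beyond the scatter), and methyl in place of cyano gives an 8.8-fold lower number from compound 1 to compound 3 (0.94 log units; beyond the scatter). With the shared core untouched, the number therefore responds to the group at this place, and among the three groups only methyl stands apart, while methoxy and cyano remain within the scatter of each other. The change from methoxy to methyl removes the oxygen and the one hydrogen-bond acceptor counted for methoxy, but no measurement shown explains why methyl stands apart from the other two groups.

Three compounds cannot show whether this gain belongs to methyl alone or also extends to ethyl, a longer chain, a chlorine atom or an amine at the same place. From the compounds shown here alone, whether methyl gives a similar step when it sits elsewhere on the same aromatic ring also remains open.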